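A few compounds are considered here, and "the series" means these few. Any claim that something is new, unique, unknown or untested is made for them only; others in the source may bear on it.

Of the compounds shown here, two built on one shared core have been measured so far. In a functional assay on HL-60 cells (Homo sapiens) for antiproliferative activity, read by MTT assay, with a stated time of 72 h (a higher number here means a weaker inhibitor, a lower number a stronger inhibitor), compound 1 `COc1cc(C(=O)c2sc3ccccc3c2-c2ccc(Cl)cc2)cc(OC)c1OC` gives 3300 nM as its reading, and compound 2 `CCOc1ccc(-c2c(C(=O)c3cc(OC)c(OC)c(OC)c3)sc3ccccc23)cc1` gives 3500 nM as its reading. For the measured compounds named here, compound 2 thus stands level with compound 1, the only other value available, and the two cannot be told apart. Going by the values given here, the one measured step is a 1.1-fold higher number from compound 1 to compound 2 (0.03 log units; within the scatter) and it puts ethoxy in place of chloro on an aromatic carbon.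

Compound 3 `COc1ccc(Nc2c(C(=O)c3cc(OC)c(OC)c(OC)c3)sc3ccccc23)cc1` differs from compound 2 elsewhere: (4-methoxyphenyl)amino in place of 4-ethoxyphenyl on an aromatic carbon with (4-methoxyphenyl)amino in place of 4-ethoxyphenyl on an aromatic carbon of the five-membered aromatic ring with 1 sulfur. The measured step exchanged only a group on the aromatic ring and kept its direct attachment to the core, so it gives little guide to the size of this change. A move toward a lower number in this assay is nonetheless expected, though this is a judgment with weak support from the data. The expected change is a 3.5-fold lower number from compound 2 to compound 3 (0.54 log units; beyond the scatter) by this estimate. For compound 3 the estimated value is 1000 nM with an expected range from 150 nM to 5000 nM in this measurement.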

Compound 3, half-maximal inhibitory concentration: 3700 nM
For compound 3 the middle estimate is 3.7-fold (0.57 log units) below the measured one; low and high end bracket the measured number.
By their numbers in this assay, from the lowest: compounds 1, 2 and 3 (each within the scatter of the next).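

In this assay the step at this place, on an aromatic carbon of the five-membered aromatic ring with 1 sulfur, gives a 1.1-fold higher number from compound 2 to compound 3 (0.02 log units; within the scatter) and, with 4-chlorophenyl as the group that leaves, a 1.1-fold higher number from compound 1 to compound 3 (0.05 log units; within the scatter). The earlier step had exchanged only a group on the outer aromatic ring, whereas here the way that ring is attached to the shared core changes too, with an amino link and its hydrogen-bond donor entering, and compounds 1, 2 and 3 still cannot be told apart. No measurement shown bears on why this change leaves the reading where it is.

On these data alone, with all three compounds within the scatter of one another, it remains open whether any group at this place can move the number, for instance a morpholine, a piperazine or a benzyl group in place of the aromatic substituents seen so far. As far as these compounds go, it is equally open whether a methyl group on the amino nitrogen of compound 3, or a methylene link in its place, would leave the reading as it stands.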